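The source may report more compounds than this note shows. Statements on the series, on what has been measured and on what is new or still open speak of the compounds shown alone.

Measured so far:
Compound 1, `COc1ccc(C2N=C(SCc3ccccc3)NC(C)=C2C(=O)Nc2ccc(F)cc2)cc1OC`, gives 8.8% in a functional assay on the whole organism (artery, strain albino) with Rattus norvegicus as the target, with a stated time of 120 min, at a dose of 10 mg/kg by the oral route; on this read-out lower numbers stand for less inhibition and higher numbers for more inhibition at the one dose given (going by the name of the read-out).
Compound 2, `COc1ccc(C2N=C(SCc3ccc(Cl)cc3)NC(C)=C2C(=O)Nc2ccc(F)cc2)cc1OC`, gives 15.5% in this assay.
Compound 3, `COc1ccc(C2N=C(SCc3ccccc3)NC(C)=C2C(=O)Nc2ccc(Br)cc2)cc1`, gives 8.2% in this assay.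

Compound 2 arises from compound 1 by one change, (chloro in place of hydrogen on an aromatic carbon), and that change made a number 6.7 percentage points higher from compound 1 to compound 2 (within the scatter). Compound 3 shares much with compound 1, but the difference between the two cores is not broken down here. Compound 4, `COc1ccc(C2N=C(SCc3ccccc3Cl)NC(C)=C2C(=O)Nc2ccc(Br)cc2)cc1`, arises from compound 3 by chloro in place of hydrogen on an aromatic carbon. This is the same kind of change as that from compound 1 to compound 2, not the same: in compound 2 the chloro sits para to a large group, in compound 4 ortho to a large group. Since the earlier step was a number 6.7 percentage points higher from compound 1 to compound 2 (within the scatter), a similarly small step, a number 4.8 percentage points higher from compound 3 to compound 4 (within the scatter), is expected. Compound 4 is therefore estimated to give 13% in this assay, roughly between 3% and 25%.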

Compound 4, a percentage reported as inhibition, in the whole organism at one dose (the size of the read-out at that dose, not a potency): 8.2%
For compound 4 the middle estimate is 4.8 percentage points above the measured one; low and high end bracket the measured number.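

Putting a chloro on the benzyl ring gave no change at the digits printed from compound 3 to compound 4 (within the scatter) in this assay. Set beside the earlier step on the other core, the two results cannot be told apart: the same change on two cores in this assay, a number 6.7 percentage points higher (within the scatter) from compound 1 to compound 2 and no change at the digits printed (within the scatter) from compound 3 to compound 4, 6.7 percentage points apart, within the scatter of two such steps So on these two cores the change gives only steps too small to read, but this does not prove that chloro is without effect, and the comparison is not exact, as the 2-chlorobenzyl group belongs to compound 4 and the chloro of compound 2 sits elsewhere on the ring.

The compounds shown leave open whether a different group on that ring, such as an amine or a carboxylic acid, would give a step beyond the scatter. They also leave open what a longer chain in place of the benzyl group would do.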